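A chloro-to-methyl swap on the way to compound 4

The source may report more compounds than this note shows. Statements on the series, on what has been measured and on what is new or still open speak of the compounds shown alone.

Values in a functional assay on MCF7 cells (Homo sapiens) for antiproliferative activity, read by MTT assay, with a stated time of 48 h (on this read-out lower numbers stand for stronger inhibition and higher numbers for weaker inhibition), for the compounds measured so far
- compound 1 `Cc1ccc(NCc2cn(-c3ccccc3)nc2-c2ccc(C)cc2)cc1` gives 7260 nM
- compound 2 `Cc1ccc(-c2nn(-c3ccccc3)cc2CNc2ccc(Br)cc2)cc1` gives 6890 nM
- compound 3 `Clc1ccc(NCc2cn(-c3ccccc3)nc2-c2ccc(Cl)cc2)cc1` gives 2280 nM

Compound 3 stands lowest of the three, and its gap to each of the others lies beyond the usual scatter. Compound 4 `Cc1ccc(-c2nn(-c3ccccc3)cc2CNc2ccc(Cl)cc2)cc1` has not yet been measured. It differs from compound 3 by methyl in place of chloro on an aromatic carbon, and the change reads 4-chlorophenyl to 4-methylphenyl. Among the compounds with values here, the one measured step is a 1.1-fold lower number from compound 1 to compound 2 (0.02 log units; within the scatter) and it leaves the 4-methylphenyl group untouched, so it does not test this change directly. The closer guide is that compound 1 at 7260 nM and compound 2 at 6890 nM both carry the 4-methylphenyl group that compound 4 gains. With so few compounds this is only a tentative reading. The expected step is a 2.6-fold higher number from compound 3 to compound 4 (0.42 log units; beyond the scatter) and so toward weaker inhibition. In this assay compound 4 is estimated at 6000 nM (expected range 3000 nM to 11000 nM).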

Compound 4, half-maximal inhibitory concentration: 6020 nM
Compound 4: the middle estimate sits 1.0-fold (0.00 log units) below what was measured, within the range that was stated.
By their numbers in this assay, from the lowest: compound 3; then compounds 4, 2 and 1 (each within the scatter of the next).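

In this assay, within the data shown here, there is a 2.6-fold higher number from compound 3 to compound 4 (0.42 log units; beyond the scatter), the first direct reading of this change, and it shows that the 4-chlorophenyl group and the 4-methylphenyl group can be told apart at this position. With the 4-methylphenyl group held, the other substituted ring gives a 1.1-fold lower number from compound 2 to compound 4 (0.06 log units; within the scatter) and a 1.2-fold lower number from compound 1 to compound 4 (0.08 log units; within the scatter), so methyl, bromo and chloro there cannot be told apart, and chloro on that ring alone does not reproduce the value of compound 3, 2280 nM. No measurement is available to explain this difference.

The compounds shown leave open whether the 4-chlorophenyl group would give the same step with bromo or methyl on the other ring. They also leave open how a methoxy group, an amine or a carboxylic acid would read at this position.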